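This account rests on a few compounds, and the source may have more. Where it says the series, first, only, none or still open, it means among the compounds named here.

Measured compounds in a functional assay on A549 cells (Homo sapiens), read by MTT assay, with a stated time of 72 h; on this read-out lower numbers stand for stronger inhibition and higher numbers for weaker inhibition:
- compound 1, `COc1ncnc2c1c(-c1ccsc1)cn2[C@@H]1O[C@H](CO)[C@@H](O)[C@H]1O`: 5170 nM
- compound 2, `C#Cc1cn([C@@H]2O[C@H](CO)[C@@H](O)[C@H]2O)c2ncnc(NC)c12`: reaches only the limit > 20000 nM
- compound 3, `CNc1ncnc2c1c(-c1ccccc1)cn2[C@@H]1O[C@H](CO)[C@@H](O)[C@H]1O`: reaches only the limit > 20000 nM

Compound 3 stands at the limit of this assay, and that value is a limit and not a number. Of the three values shown, two sit at that same ceiling (the limit of > 20000 nM in this assay, at which 2 of the 3 values shown sit); compound 1 alone gives a number. Within the data shown here, the single step between measured neighbours, a step that the two limits leave unreadable from compound 2 to compound 3, runs from one limit to another and its size cannot be read.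

The next compound, compound 4, `CNc1ncnc2c1c(-c1ccsc1)cn2[C@@H]1O[C@H](CO)[C@@H](O)[C@H]1O`, differs from compound 3 in one place: thiophen-3-yl in place of phenyl on an aromatic carbon

No measured step changes phenyl into thiophen-3-yl, so nothing shown bears directly on this change. What can be said is that compound 1, which also carries thiophen-3-yl but differs from compound 4 elsewhere, gives a number in this assay, whereas compound 3 only reaches the limit. For compound 4 the step of an at least 1.4-fold lower number from compound 3 to compound 4 (0.15 log units; that floor lies within the scatter) is therefore estimated to be, at most, a modest gain that may still end at the limit. Compound 4 is expected to give about 14000 nM, within 4000 nM to 40000 nM.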

Compound 4, half-maximal inhibitory concentration: > 20000 nM
Compound 4 ended at the assay's limit; the forecaster's own chance of this, stated with the estimate: 50%; middle value at least 1.4-fold (0.15 log units) away from the limit.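

In this assay compound 4 gives > 20000 nM, which is a limit and not a number. Thiophen-3-yl at this aromatic carbon therefore does not bring a number with methylamino on the core, and the steps among compound 2, compound 3 and compound 4 cannot be read. The one readable step is an at least 3.8-fold higher number from compound 1 to compound 4 (0.58 log units; beyond the scatter), with methylamino in place of methoxy on an aromatic carbon, so the only measurable change so far lies at that other carbon and not at the thiophen-3-yl position, and most of the series sits at one ceiling: the limit of > 20000 nM in this assay, at which 3 of the 4 values shown sit.

On these data alone, whether phenyl or ethynyl would also give a number alongside methoxy remains open. Also open, as far as these compounds go, is whether an unsubstituted amine or a longer alkoxy chain in place of methoxy would hold, gain or lose the activity of compound 1.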